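The source may report more compounds than this note shows. Statements on the series, on what has been measured and on what is new or still open speak of the compounds shown alone.

Measured in an ADME assay on MDCK cells (Canis lupus familiaris) for cytotoxicity, with a stated time of 48 h; on this read-out higher numbers stand for lower toxicity in this test and lower numbers for higher toxicity in this test:
- compound 1 (`CCC(CC)O[C@@H]1C=C(S(C)(=O)=O)C[C@H](N)[C@H]1NC(C)=O`) gives "not determined" (no result reported)
- compound 2 (`CCC(CC)O[C@@H]1C=C(S(C)(=O)=O)C[C@H](NC(=N)N)[C@H]1NC(C)=O`) gives > 100000 nM as a limit
- compound 3 (`CCC(CC)O[C@@H]1C=C([S+]([O-])O)C[C@H](NC(=N)N)[C@H]1NC(C)=O`) gives > 100000 nM as a limit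

Compound 2 gives > 100000 nM as a limit and not a number, so it has no exact place in the series. For the measured compounds named here, the one measured change is a step that the two limits leave unreadable from compound 2 to compound 3 and offers no size to carry over. Compound 4 (`CCC(CC)O[C@@H]1C=C(S(=O)(=O)OCCCc2ccccc2)C[C@H](NC(=N)N)[C@H]1NC(C)=O`) follows with 3-phenylpropoxy in place of methyl on a sulfonyl sulfur as its change, 3-phenylpropoxy in place of methyl on a sulfonyl sulfur. The remaining footing is the limit of > 100000 nM in this assay, at which 2 of the 3 values shown sit, and compound 4 is expected to stay near that limit. In this assay the expected step is a number no higher from compound 2 to compound 4 (the limit leaves the size open) and none beyond the scatter is expected, with any drift toward lower numbers. For compound 4 the estimated value is 100000 nM (expected range 30000 nM to 300000 nM).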

Compound 4, half-maximal cytotoxic concentration: > 100000 nM
Compound 4: no number, only a limit; the forecaster's own chance of this, stated with the estimate: 75%; the middle value lies on the limit itself.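

In this assay compound 4 gives > 100000 nM, a limit and not a number, so no step can be read between compound 2 and compound 4. The compounds shown leave open whether 3-phenylpropoxy in place of methyl on the sulfonyl sulfur changes this read-out at all.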